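The source may hold more compounds than are shown below. What is called first, only, known or untested is meant among the compounds shown, and "the series" means these compounds.

Measured so far:
- compound 1, `N[C@]1(CO)CC[C@H](c2ccc3c(c2)CC[C@H](COCc2ccccc2)C3)C1`: 0%
- compound 2, `N[C@]1(CO)CC[C@H](c2ccc3c(c2)CC[C@@H](COCc2ccccc2)C3)C1`: 49%
- compound 3, `COc1cccc(CO[C@@H]2CCc3cc([C@H]4CC[C@](N)(CO)C4)ccc3C2)c1`: 15%

In a functional assay on the whole organism (strain Lewis) with Rattus norvegicus as the target, with a stated time of 24 h, at a dose of 0.3 mg/kg by the oral route (on this read-out lower numbers stand for less inhibition and higher numbers for more inhibition at the one dose given (going by the name of the read-out)), compound 1 gives 0%, the lowest of the three numbers shown. Going by the values given here, compound 2 has the same atoms and bonds and gives 49%; the step of a number 49 percentage points higher from compound 1 to compound 2 (beyond the scatter) is the only measured step here, and it rests on (the fact that compounds 1 and 2 differ only in the configuration as drawn), so it says nothing about swapping one group for another. Among the compounds with values here, compound 3 carries a different side group and gives 15%, but no single-change step links it to compound 1, so its value only shows where it lies.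

Compound 4, `COc1cccc(OC[C@H]2CCc3cc([C@H]4CC[C@](N)(CO)C4)ccc3C2)c1`, differs from compound 1 by 3-methoxyphenyl in place of benzyl on an oxygen on a saturated carbon. Within the data shown here, no measured step bears on this change, so there is no ground to expect a shift beyond the scatter in this assay. The expected step is a number 10 percentage points higher from compound 1 to compound 4 (within the scatter), small and uncertain. Compound 4 is therefore estimated at 10%, with a range from 0% to 35%.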

Compound 4, a percentage reported as inhibition, in the whole organism at one dose (the size of the read-out at that dose, not a potency): 70%
Beside the measured number, compound 4's estimate is 60 percentage points below it; the measured number lies above the stated range.
By their numbers in this assay, from the lowest: compound 1; then compound 3; then compound 2; then compound 4.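

In this assay, a number 70 percentage points higher from compound 1 to compound 4 (beyond the scatter), so the group on this oxygen can change the read-out greatly even at this single low dose. Going by these compounds alone, the only other measured step, a number 49 percentage points higher from compound 1 to compound 2 (beyond the scatter), is a change of configuration with the atoms unchanged, whereas this step replaces one group with another. The swap alters two things at once, since benzyl gives way to a ring bearing a methoxy group and the benzyloxy to 3-methoxyphenoxy difference also removes the carbon between the oxygen and the ring, and this single step cannot show how much each contributes.

Nothing measured here explains why this swap has so large an effect. A plain phenyl on that oxygen would help separate the two changes, and a ring carrying an amine or a carboxylic acid instead of methoxy remains an open case.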